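The compounds below may be only part of what the source reports. "The series", "measured", "known", "first", "only" and "open" are said of these compounds alone.

Among the compounds with values here, compound 3 `COC(=O)C(=O)NC1=C(C#N)C2C(N3CCCC3)CCCCN2C(=O)N1c1ccccc1` gives 89.8% in a functional assay on the whole organism (strain albino) for inhibition, with Rattus norvegicus as the target, read by paw edema, with stated times of 1 h and 3 h, at a dose of 24 mmol/kg by the intraperitoneal route (a lower number here means a weaker effect, a higher number a stronger effect of the compound at the dose given), the lowest of the three numbers so far, though it stands within the scatter of compound 2 `N#CC1=C(/N=C/c2ccc([N+](=O)[O-])cc2)N(c2ccccc2)C(=O)N2CCCCC(N3CCCC3)C12`, which gives 90.8%, and of compound 1 `N#CC1=C(NCC(=O)O)N(c2ccccc2)C(=O)N2CCCCC(N3CCCC3)C12`, which gives 91.4%.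

Compound 4 `N#CC1=C(N)N(c2ccccc2)C(=O)N2CCCCC(N3CCCC3)C12` has not been measured. It differs from compound 3 in one place: hydrogen in place of (methoxycarbonyl)carbonyl on an amine nitrogen. Every measured step in the series touches this same position. The exchange on the amine nitrogen gave a number 1.6 percentage points lower from compound 1 to compound 3 (within the scatter); the exchange on the double-bonded ring carbon gave a number 0.6 percentage points lower from compound 1 to compound 2 (within the scatter) and a number 1 percentage points lower from compound 2 to compound 3 (within the scatter). Three quite different groups at that position therefore return numbers that cannot be told apart. Within the data shown here, none of the measured steps removes the substituent entirely and leaves only hydrogen, so the step from compound 3 to compound 4 is not covered directly. On the numbers available the size of the group at this position has not mattered, and the expectation for this assay is a step of no size beyond the scatter, in either direction; the step expected from compound 3 to compound 4 is a number 1.8 percentage points lower from compound 3 to compound 4 (within the scatter).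

For compound 4 the estimate in this assay is 88%, expected to lie between 76% and 95%.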

Compound 4, a percentage reported as inhibition, in the whole organism at one dose (the size of the read-out at that dose, not a potency): 89.3%
The estimate for compound 4 lay 1.3 percentage points below the measured number, within the range that was stated.
By their numbers in this assay, from the lowest: compounds 4, 3, 2 and 1 (each within the scatter of the next).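

Leaving only hydrogen on the amine nitrogen gives, in this assay, a number 0.5 percentage points lower from compound 3 to compound 4 (within the scatter) and a number 1.5 percentage points lower from compound 2 to compound 4 (within the scatter) and also a number 2.1 percentage points lower from compound 1 to compound 4 (within the scatter) as the three new steps. The earlier compounds shown here compared only one substituent with another, whereas compound 4 adds the bare amino group and shows that, at this single dose, the paw edema read-out stays within the scatter with or without a substituent at this position, so the (methoxycarbonyl)carbonyl group of compound 3 and the different groups of compound 1 and compound 2 cannot be told apart from hydrogen here. No measurement at hand accounts for this flat result.

All four compounds are compared at one dose, so this read-out gives the size of the effect at that dose and leaves open whether any of them would show a stronger or weaker effect at another dose. Also open, as far as these compounds go, is whether the flat result holds for other groups on the amine nitrogen, such as an acetyl group, a methyl group or a longer alkyl chain, and whether it holds when the nitrile or the phenyl group of the shared core is exchanged.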